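The source may hold more compounds than are shown below. What is called first, only, known or untested is meant among the compounds shown, and "the series" means these compounds.

Within the data shown here, in a functional assay on A549 cells (Homo sapiens) for cytotoxicity, read by resazurin assay, with a stated time of 48 h (a higher number here means a weaker inhibitor, a lower number a stronger inhibitor), compound 1 (`C=C(C)[C@@H]1CC=C(CN(OC)C2O[C@H](CO)[C@@H](N=[N+]=[N-])[C@H](O)[C@H]2O)CC1`) gives 4000 nM, the lowest of the three numbers so far. Compound 2 (`C=C(C)[C@@H]1CC=C(CN(OC)C2O[C@@H](CO)[C@H](N=[N+]=[N-])[C@@H](O)[C@@H]2O)CC1`) gives 451000 nM, and compound 3 (`C=C(C)[C@@H]1CC=C(CN(OC)[C@@H]2O[C@H](CO)[C@@H](O)[C@H](O)[C@H]2NC(=O)N(C)N=O)CC1`) gives 185000 nM.

Next in the series is compound 4 (`C=C(C)[C@@H]1CC=C(CN(OC)C2O[C@H](CN=[N+]=[N-])[C@@H](N=[N+]=[N-])[C@H](O)[C@H]2O)CC1`), which keeps the core of compound 1 and changes one group: azido in place of hydroxy on a saturated chain carbon bound to a saturated ring carbon. In words, this is azido in place of hydroxy on a saturated chain carbon bound to a saturated ring carbon, or hydroxymethyl to azidomethyl.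

Among the measured compounds shown here, no measured step touches this place. For the measured compounds named here, the one measured step, a 110-fold higher number from compound 1 to compound 2 (2.05 log units; beyond the scatter), keeps atoms and bonds and alters configuration only; what goes with it is the fact that one of compounds 1 and 2 is drawn with a defined configuration and the other without, at the place where they differ. It bears on the swap only indirectly, showing how far the number can move within this series.

Going by the values given here, with no direct precedent, a small step in this assay is expected, leaning towards a higher number and far smaller than that configurational step. The estimate amounts to an expected 1.5-fold higher number from compound 1 to compound 4 (0.18 log units; within the scatter). Compound 4 is estimated at 6000 nM, with an expected range of 1500 nM to 30000 nM.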

Compound 4, half-maximal inhibitory concentration: 44000 nM
Estimate against measurement, compound 4: 7.3-fold (0.87 log units) below; the measured number lies above the stated range.
By their numbers in this assay, from the lowest: compound 1; then compound 4; then compound 3; then compound 2.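

In this assay the place on a saturated chain carbon bound to a saturated ring carbon proves sensitive: azido in place of hydroxy gives an 11-fold higher number from compound 1 to compound 4 (1.04 log units; beyond the scatter) with the configuration of the core left as drawn. Among these compounds, until now the only step was configurational, a 110-fold higher number from compound 1 to compound 2 (2.05 log units; beyond the scatter) being the larger of the two, so this is the first sign that a change of group alone on the core of compound 1 can also move the number well beyond the scatter. Nothing available bears on why hydroxymethyl to azidomethyl has this effect.

The compounds shown carry only hydroxymethyl and azidomethyl at this place, so aminomethyl, methoxymethyl or a carboxylic acid there would test whether the step belongs to azido specifically or to the loss of hydroxy. On these data alone, how the same swap reads on the configuration of compound 2 also stays open.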